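Small alkyl groups on the core: compound 4

The source may report more compounds than this note shows. Statements on the series, on what has been measured and on what is new or still open speak of the compounds shown alone.

Compound 1 `C[C@H](NC(=O)c1c(C(F)(F)F)nnn1Cc1ccc(C(F)(F)F)cc1)c1ccc(C(=O)O)cc1` in a functional assay on CHO cells for antagonist activity at prostaglandin E2 receptor EP4 subtype (Homo sapiens), read by calcium flux, with a stated time of 15 min (on this read-out lower numbers stand for stronger inhibition and higher numbers for weaker inhibition), gives 225 nM. Compound 2 `Cc1nnn(Cc2ccc(C(F)(F)F)cc2)c1C(=O)N[C@@H](C)c1ccc(C(=O)O)cc1` gives only a limit of the assay, > 10000 nM. Compound 3 `CCc1nnn(Cc2ccc(C(F)(F)F)cc2)c1C(=O)N[C@@H](C)c1ccc(C(=O)O)cc1` likewise gives only a limit, > 10000 nM. On the numbers shown, compound 3 therefore stands at the limit of the assay, where one further value also sits (the limit of > 10000 nM in this assay, at which 2 of the 3 values shown sit). The steps of an at least 44-fold higher number from compound 1 to compound 2 (1.64 log units; beyond the scatter) and an at least 44-fold higher number from compound 1 to compound 3 (1.64 log units; beyond the scatter) both replace trifluoromethyl on the core by a small alkyl group and both are large. The step that the two limits leave unreadable from compound 2 to compound 3 cannot be read, since both ends are limits.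

Compound 4 `C[C@H](NC(=O)c1c(C2CC2)nnn1Cc1ccc(C(F)(F)F)cc1)c1ccc(C(=O)O)cc1` differs from compound 3 by cyclopropyl in place of ethyl on an aromatic carbon of a five-membered aromatic ring with 3 nitrogen. The two alkyl replacements already measured bear on it: methyl and ethyl at this place both gave only limits, and cyclopropyl is a third small alkyl there. Within the data shown here, the step that the limit leaves unreadable from compound 3 to compound 4 is therefore expected to leave compound 4 at or near the limit, with no step readable beyond the scatter. For compound 4 the estimate is 15000 nM, between 2500 nM and 80000 nM, most likely reported again as a limit.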

Compound 4, half-maximal inhibitory concentration: 52.1 nM
Estimate against measurement, compound 4: 290-fold (2.46 log units) above, outside the stated range (below it).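

In this assay, this position does not turn away every small carbon group: cyclopropyl in place of ethyl gives an at least 190-fold lower number from compound 3 to compound 4 (2.28 log units; beyond the scatter), and cyclopropyl in place of methyl gives an at least 190-fold lower number from compound 2 to compound 4 (2.28 log units; beyond the scatter). Among these compounds, both steps are bounded on one side only, since compound 2 and compound 3 remain limits: the limit of > 10000 nM in this assay, at which 2 of the 4 values shown sit. Cyclopropyl also goes beyond trifluoromethyl, with a 4.3-fold lower number from compound 1 to compound 4 (0.64 log units; beyond the scatter), so trifluoromethyl is not the only group here that keeps a measurable value.

The compounds shown cannot separate the three-membered ring from the carbon count, a question that a propyl chain, an isopropyl group or a cyclobutyl ring at this place would bear on. From the compounds shown here alone, how far the position tolerates heteroatoms, such as in a methoxy group or an amine, also stays open.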